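Replacing the benzyl of compound 3 with a propyl chain

This account rests on a few compounds, and the source may have more. Where it says the series, first, only, none or still open, it means among the compounds named here.

Of the compounds shown here, three sharing one core have been measured in a functional assay on HCT-116 cells (Homo sapiens) for antiproliferative activity, read by CCK-8 assay, with a stated time of 72 h, tested at 8 uM; a higher number here means a stronger effect of the compound at the concentration tested, a lower number a weaker effect. Compound 1 `COC(CCn1cnc2c(NCc3ccc(C(=O)Nc4ccccc4N)cc3)nc(Cl)nc21)OC` gives 11.9% in this assay, compound 2 `Nc1ccccc1NC(=O)c1ccc(CNc2nc(Cl)nc3c2ncn3C2CCCC2)cc1` gives 80.6%, and compound 3 `Nc1ccccc1NC(=O)c1ccc(CNc2nc(Cl)nc3c2ncn3Cc2ccccc2)cc1` gives 11.5%. Compound 3 thus stands lowest of the three, with compound 1 nearest, within the scatter, and compound 2 furthest, beyond it. The steps between them show that a number 0.4 percentage points lower from compound 1 to compound 3 (within the scatter), whereas a number 69.1 percentage points lower from compound 2 to compound 3 (beyond the scatter) and a number 68.7 percentage points higher from compound 1 to compound 2 (beyond the scatter).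

Compound 4 `CCCn1cnc2c(NCc3ccc(C(=O)Nc4ccccc4N)cc3)nc(Cl)nc21` differs from compound 3 in one place: ethyl in place of phenyl on a saturated chain carbon bound to an aromatic nitrogen. Cut one bond further out, the same difference reads benzyl to propyl. Within the data shown here, two measured steps bear on it. The step from compound 1 to compound 3 exchanged groups at the same saturated chain carbon and stayed within the scatter, so a change at this position has so far moved nothing. The step from compound 2 to compound 3 was large, but it involved cyclopentyl, which compound 4 does not carry; compound 1, the other open-chain compound, sits close to compound 3. Compound 4 is therefore expected to show a number 6.5 percentage points higher from compound 3 to compound 4 (within the scatter), a step within the scatter. Compound 4 is estimated at 18%, within a range of 4% to 42%.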

Compound 4, a percentage reported as inhibition, at one concentration (the size of the read-out at that concentration, not a potency): 29.6%
Estimate against measurement, compound 4: 11.6 percentage points below; low and high end bracket the measured number.
By their numbers in this assay, from the lowest: compounds 3 and 1 (each within the scatter of the next); then compound 4; then compound 2.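

At the saturated chain carbon bound to an aromatic nitrogen, the earlier compounds had shown no movement, but in this assay ethyl in place of phenyl gives a number 18.1 percentage points higher from compound 3 to compound 4 (beyond the scatter), so this position does respond to the group placed on it. Methyl in place of dimethoxymethyl, on a saturated chain carbon two bonds along the chain from an aromatic nitrogen, gives a number 17.7 percentage points higher from compound 1 to compound 4 (beyond the scatter), which separates the plain propyl chain from the dimethoxy-bearing chain of compound 1, a separation that the benzyl of compound 3 did not show. The plain chain still falls well short of the ring, as exchanging the cyclopentyl for the propyl chain gives a number 51 percentage points lower from compound 2 to compound 4 (beyond the scatter). Nothing in the data shown offers a reason for any of these steps.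

The compounds shown leave open whether a longer chain such as butyl would move further towards compound 2 or whether the high number depends on a saturated ring, which cyclobutyl or cyclohexyl on the same aromatic nitrogen could test. They also leave open how an amine or a carboxylic acid at the end of the propyl chain would compare with compound 4.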